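This account rests on a few compounds, and the source may have more. Where it says the series, first, only, none or still open, it means among the compounds named here.

Measured so far: compound 1 `CC1=C(C(=O)Nc2ccc(F)c(Cl)c2)C(c2cccc(Oc3ccccc3)c2)NC(=O)N1` gives 7590 nM; compound 2 `CC1=C(C(=O)Nc2ccc(F)c(Cl)c2)C(c2ccccc2Cl)NC(=S)N1` gives 12300 nM; compound 3 `CC1=C(C(=O)Nc2ccc(Cl)c(Cl)c2)C(c2ccccc2Cl)NC(=S)N1` gives 10000 nM in a functional assay on SK-MEL-5 cells (Homo sapiens) for cytotoxicity, read by sulforhodamine B assay, with a stated time of 48 h; on this read-out lower numbers stand for stronger inhibition of growth and higher numbers for weaker inhibition of growth.

Compound 2 has the largest of the three numbers, though all three sit within the scatter of one another. Compound 4 `COc1cccc(C2NC(=S)NC(C)=C2C(=O)Nc2ccc(F)c(Cl)c2)c1` differs from compound 2 in one place: 3-methoxyphenyl in place of 2-chlorophenyl on a saturated ring carbon. Going by the values given here, no measured step changes this position of the shared core. Among the compounds with values here, the one step available, a 1.2-fold lower number from compound 2 to compound 3 (0.09 log units; within the scatter), alters a different part and is within the scatter. Compound 1 carries another aromatic group at the same place but also a different core, so its value and that of compound 2 only show two numbers within the scatter. For compound 4 the step of a 1.2-fold lower number from compound 2 to compound 4 (0.09 log units; within the scatter) is therefore expected to stay within the scatter. Compound 4 is estimated at 10000 nM, between 3500 nM and 30000 nM.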

Compound 4, concentration for 50% growth inhibition: 13200 nM
Beside the measured number, compound 4's estimate is 1.3-fold (0.12 log units) below it; the measured number falls inside the stated range.
By their numbers in this assay, from the lowest: compounds 1, 3, 2 and 4 (each within the scatter of the next).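

In this assay this saturated ring carbon of the shared core now has a measured step of its own: 3-methoxyphenyl in place of 2-chlorophenyl gives a 1.1-fold higher number from compound 2 to compound 4 (0.03 log units; within the scatter). Exchanging these two aromatic groups, with the hydrogen-bond acceptor that 3-methoxyphenyl brings, thus leaves the two numbers within the scatter of each other. No available evidence offers an explanation for this result. The compounds shown leave open whether a group without an aromatic ring at this place, such as a butyl chain or an aminomethyl group, would give a step beyond the scatter.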